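The source may report more compounds than this note shows. Statements on the series, on what has been measured and on what is new or still open speak of the compounds shown alone.

Measured in a functional assay on A-431 cells (Homo sapiens) for inhibition, with a stated time of 72 h; a lower number here means a stronger inhibitor, a higher number a weaker inhibitor:
- compound 1 `COCc1cc(CN2CCCC2)c(O)c2ncccc12`: 52500 nM
- compound 2 `COCc1cc(CN2CCCCC2)c(O)c2ncccc12`: 22400 nM
- compound 3 `CC1CCN(Cc2cc(Cl)c3cccnc3c2O)CC1`: 8710 nM

Compound 3 has the lowest of the three numbers, so it is the strongest inhibitor so far. Compound 4 `COCc1cc(CN2CCC(C)CC2)c(O)c2ncccc12` departs from it by one change, (methoxymethyl in place of chloro on an aromatic carbon), with methoxymethyl in place of chloro on an aromatic carbon. Among the compounds with values here, the only measured step, a 2.3-fold lower number from compound 1 to compound 2 (0.37 log units; beyond the scatter), concerns the amine and not this place, so it bears only indirectly. Compounds 1 and 2 both carry methoxymethyl, and both stand higher than compound 3. A modest rise in this assay is therefore expected, an estimated 1.8-fold higher number from compound 3 to compound 4 (0.26 log units; within the scatter) in size. For compound 4 the expected value is 16000 nM, within an estimated range of 7000 nM to 37000 nM as the likely span.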

Compound 4, half-maximal inhibitory concentration: 13800 nM
Estimate against measurement, compound 4: 1.2-fold (0.06 log units) above, and the stated range covers the measured number.
By their numbers in this assay, from the lowest: compounds 3, 4 and 2 (each within the scatter of the next, the first and the last beyond it); then compound 1.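

In this assay, methoxymethyl in place of chloro on the aromatic carbon para to the hydroxy group gives a 1.6-fold higher number from compound 3 to compound 4 (0.20 log units; within the scatter), so this assay does not separate the two groups at this position. With methoxymethyl kept, the added methyl on the saturated ring carbon gives a 1.6-fold lower number from compound 2 to compound 4 (0.21 log units; within the scatter), while 4-methylpiperidin-1-yl in place of pyrrolidin-1-yl gives a 3.8-fold lower number from compound 1 to compound 4 (0.58 log units; beyond the scatter), and only the latter is beyond the scatter. No available evidence accounts for these steps.

From the compounds shown here alone, it remains open how an amine or a carboxylic acid at this position would compare with chloro and methoxymethyl. The same holds for a longer chain such as ethoxymethyl.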